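Swapping the Enone Direction on a Fused Core

A few compounds are considered here, and "the series" means these few. Any claim that something is new, unique, unknown or untested is made for them only; others in the source may bear on it.

Measured so far:
compound 1, `COc1ccc(-c2cc(C(=O)/C=C/c3ccccc3)nc3cc(-c4ccccc4)nn23)cc1OC`: 64100 nM
compound 2, `COc1ccc(-c2cc(C(=O)/C=C/c3ccc(C)cc3)nc3cc(-c4ccccc4)nn23)cc1OC`: 57400 nM

In an ADME assay on HEK293 cells (Homo sapiens) for antiproliferative activity, read by MTT assay, with a stated time of 24 h (a higher number here means a weaker inhibitor, a lower number a stronger inhibitor), compound 2 gives 57400 nM, the lower of the two numbers, with compound 1 close by, as a 1.1-fold lower number from compound 1 to compound 2 (0.05 log units; within the scatter) shows. Compound 3, `COc1ccc(-c2cc(/C=C/C(=O)c3ccc(Cl)cc3)nc3cc(-c4ccccc4)nn23)cc1OC`, is not yet measured. It differs from compound 2 by 2-((4-chlorophenyl)carbonyl)ethenyl in place of (2-(4-methylphenyl)ethenyl)carbonyl on an aromatic carbon. Going by the values given here, the only measured step, from compound 1 to compound 2, stayed within the scatter; no step covers the reversed carbonyl placement or the chlorine. Compound 3 is therefore expected to sit near compound 2, a step of a 1.0-fold lower number from compound 2 to compound 3 (0.02 log units; within the scatter), estimated at 55000 nM within 25000 nM to 120000 nM.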

Compound 3, half-maximal inhibitory concentration: 44100 nM
Beside the measured number, compound 3's estimate is 1.2-fold (0.10 log units) above it; low and high end bracket the measured number.
By their numbers in this assay, from the lowest: compounds 3, 2 and 1 (each within the scatter of the next).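

Exchanging the (2-phenylethenyl)carbonyl or (2-(4-methylphenyl)ethenyl)carbonyl group for 2-((4-chlorophenyl)carbonyl)ethenyl reverses the order of carbonyl and double bond on the aromatic carbon, yet in this assay both steps stay within the scatter: a 1.3-fold lower number from compound 2 to compound 3 (0.11 log units; within the scatter) and a 1.5-fold lower number from compound 1 to compound 3 (0.16 log units; within the scatter). So this position tolerates a larger rearrangement than the earlier methyl step, with no clear change in the number. Nothing available explains this result.

As far as these compounds go, the reversal and the chlorine arrive together, so their separate contributions remain unknown. From the compounds shown here alone, whether an amine or a carboxylic acid at this position would shift the number also remains open.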